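A few compounds are considered here, and "the series" means these few. Any claim that something is new, unique, unknown or untested is made for them only; others in the source may bear on it.

Of the compounds shown here, two of a shared core have been measured in a functional assay on BJAB cells (Homo sapiens) for antiproliferative activity, with a stated time of 4 days; a lower number here means that less compound is needed, a higher number that more compound is needed for the effect. Compound 1, `COC(=O)c1c(Cc2ccccc2[N+](=O)[O-])c(C)nn1-c1nc(-c2ccc(Cl)c(Cl)c2)cs1`, gives in this assay a value of 377000 nM. Compound 2, `CC(=O)Nc1ccc(-c2c(C)nn(-c3nc(-c4ccc(Cl)c(Cl)c4)c(SC(C)C)s3)c2C(=O)O)cc1`, gives in this assay a value of 139000 nM, which is the lower of the two numbers; compound 1 sits beyond the scatter above it. Going by the values given here, with only two compounds measured and no change between them counted as a single step, no pattern of structure against activity can yet be drawn from them.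

Compound 3, `Cc1cc(C)cc(-c2c(C)nn(-c3nc(-c4ccc(Cl)c(Cl)c4)c(SC(C)C)s3)c2C(=O)O)c1`, has not been measured. It differs from compound 2 in one place: 3,5-dimethylphenyl in place of 4-acetamidophenyl on an aromatic carbon. The group that leaves carries a hydrogen-bond donor and acceptor, the group that enters carries none, so the change removes both from that position on the core.

Among the compounds with values here, nothing measured so far tells how this position responds. Compound 3 is therefore expected to stay in the same weak range as compound 2, with a step of a 1.3-fold lower number from compound 2 to compound 3 (0.10 log units; within the scatter) that is estimated to lie within or near the scatter. The estimate for compound 3 in this assay is 110000 nM, expected between 30000 nM and 400000 nM.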

Compound 3, half-maximal effective concentration: 2700 nM
Compound 3: middle estimate off by 41-fold (1.61 log units), on the high side, and the stated range ends above it.
By their numbers in this assay, from the lowest: compound 3; then compound 2; then compound 1.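

Going by these compounds alone, the aromatic carbon that carries this aryl group, next to the ring atom that bears a carboxy group, turns out to respond strongly to what is placed on it: in this assay, 3,5-dimethylphenyl in place of 4-acetamidophenyl gives a 51-fold lower number from compound 2 to compound 3 (1.71 log units; beyond the scatter) and so lifts the series out of the weak range held by the earlier compounds. The six-membered aromatic ring of carbon only is present on both sides of the step, so the difference lies in the groups on that ring: the hydrogen-bond donor and acceptor of the acetamido group are gone, and two methyl groups have come in. No measurement bears on why the step is this large.

The compounds shown do not separate the loss of the acetamido group from the arrival of the two methyl groups, and an unsubstituted phenyl at this carbon would be needed to tell these apart. On these data alone, it also stays open whether other groups on the ring, such as an amine or methoxy groups in place of the methyl groups, would keep a value in this range.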